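Swapping the ring on the core nitrogen: methoxycyclohexyl to hydroxycyclopentyl

The source may hold more compounds than are shown below. What is called first, only, known or untested is meant among the compounds shown, and "the series" means these compounds.

Compound 1: `Nc1ncnc2c1c(Oc1cccc(C(F)(F)F)c1)nn2[C@H]1C[C@H](O)C1`, 0.367 h
Compound 2: `CO[C@H]1CC[C@H](n2nc(Oc3cc(C(F)(F)F)ccn3)c3c(N)ncnc32)CC1`, 0.217 h

Of the compounds shown here, two share a core and have been measured in an ADME assay on microsomes from liver (Mus musculus) for metabolic stability, read by LC-MS, using NADPH, with a stated time of 10 min, tested at 10 uM; on this read-out higher numbers stand for a longer-lived compound and lower numbers for a shorter-lived compound. Compound 1 gives 0.367 h. Compound 2 gives 0.217 h, the lowest of the two numbers; its nearest neighbour is compound 1, and the gap between them lies within the usual scatter of this measurement, so no order between the two can be read from it.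

Compound 3, `Nc1ncnc2c1c(Oc1cc(C(F)(F)F)ccn1)nn2C1CCC(O)C1`, has not yet been measured. It differs from compound 2 in one place: 3-hydroxycyclopentyl in place of 4-methoxycyclohexyl on an aromatic nitrogen. Going by the values given here, no measured pair shows this change on its own, so nothing here tells how large its effect is. With only compound 1 and compound 2 as guides, and both close together, the step from compound 2 to compound 3 is expected to be small, a 1.4-fold higher number from compound 2 to compound 3 (0.14 log units; within the scatter), most likely within the scatter. Compound 3 is therefore estimated at 0.3 h, with a plausible range from 0.15 h to 0.6 h.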

Compound 3, half-life: 0.3 h
The estimate for compound 3 equals the measured number at the digits printed, and the stated range covers the measured number.
By their numbers in this assay, from the lowest: compounds 2, 3 and 1 (each within the scatter of the next).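

Going by these compounds alone, compounds 2 and 3 form the first pair here that differs only on the aromatic nitrogen of the shared core. In this assay the exchange of 4-methoxycyclohexyl for 3-hydroxycyclopentyl gives a 1.4-fold higher number from compound 2 to compound 3 (0.14 log units; within the scatter) and so this half-life does not tell the two groups apart. At this position, a six-membered ring bearing a methoxy group and a five-membered ring bearing a hydroxyl group can therefore be exchanged with no readable shift in this read-out, and nothing available accounts for this result.

Within the data shown here, the single step changes ring size and the oxygen substituent together, so the part played by each remains open. A 4-hydroxycyclohexyl group would separate the two, while an aminocyclohexyl group or an open propyl chain would test whether this position stays as undemanding with other groups.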